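The source may hold more compounds than are shown below. What is called first, only, known or untested is meant among the compounds shown, and "the series" means these compounds.

Measured compounds:
- compound 1 `CCN(CC)c1nc(C)nc2c(-c3ccc(OC)c(C)c3C)c(C)nn12`: 38.6 nM
- compound 2 `CCOCC(COCC)Nc1nc(C)nc2c(-c3ccc(OC)cc3C)c(C)nn12`: 19.3 nM
- compound 3 `CCC1CCCCN1c1nc(C)nc2c(-c3c(C)cc(OC)cc3OC)c(C)nn12`: 3.26 nM

In an assay on cell membranes for displacement of a labelled ligand from corticotropin-releasing factor receptor 1 (Rattus norvegicus) (a higher number here means a weaker inhibitor, a lower number a stronger inhibitor), compound 2 gives 19.3 nM, the second highest of the three numbers. Its nearest neighbour is compound 1, which in this assay gives 38.6 nM, a gap that stays within the scatter; the furthest is compound 3, which gives 3.26 nM, a gap beyond the scatter. None of the three differ in one place only, so no single step can be read off.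

Compound 4 `COc1ccc(-c2c(C)nn3c(NC4CCC4)nc(C)nc23)c(C)c1` is not yet measured. It differs from compound 2 as follows: cyclobutyl in place of 2-ethoxy-1-(ethoxymethyl)ethyl on a nitrogen on an aromatic ring. Among the measured compounds shown here, no measured pair shows this change, and the three measured compounds vary at several places at once, so the direction is uncertain. The expectation is a modest weakening, with the step from compound 2 to compound 4 estimated at a 2.1-fold higher number from compound 2 to compound 4 (0.32 log units; beyond the scatter), of a size near the edge of the scatter. Compound 4 is therefore expected to give about 40 nM, with a range from 10 nM to 160 nM.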

Compound 4, half-maximal inhibitory concentration: 24.6 nM
Estimate against measurement, compound 4: 1.6-fold (0.21 log units) above; the measured number falls inside the stated range.
By their numbers in this assay, from the lowest: compound 3; then compounds 2, 4 and 1 (each within the scatter of the next).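

In this assay, replacing 2-ethoxy-1-(ethoxymethyl)ethyl with cyclobutyl gives a 1.3-fold higher number from compound 2 to compound 4 (0.11 log units; within the scatter), the first single-place step available in the series. At this nitrogen on an aromatic ring, the larger open chain with its hydrogen-bond acceptors and the small carbon-only ring therefore cannot be told apart in this pair, so neither the acceptors nor the open chain is shown to be required for a number at this level. No measurement at hand bears on why the two groups read alike.

Going by these compounds, it remains open whether other groups on this nitrogen, such as cyclopentyl, a hydroxyl-bearing chain or a longer unbranched alkyl chain, would also leave the number unchanged. On these data alone, it is also open whether this step carries over to the different aromatic substituents of compound 1 and compound 3.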